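Thiourea Aryl Ring Exchanged for Pyridin-3-yl: Expected Potency

The source may hold more compounds than are shown below. What is called first, only, known or untested is meant among the compounds shown, and "the series" means these compounds.

Of the compounds shown here, three with a shared core have been measured in a functional assay on MKN-74 cells (Homo sapiens) for antiproliferative activity, with a stated time of 24 h; on this read-out lower numbers stand for stronger inhibition and higher numbers for weaker inhibition. Compound 1 `NC(=O)c1c(NC(=O)c2ccccc2Cl)sc2c1CCN(Cc1ccc(Cl)cc1)C2` gives 18700 nM. Compound 2 `NC(=O)c1c(NC(=O)c2ccccc2Cl)sc2c1CCN(C(=S)Nc1ccccc1C(F)(F)F)C2` gives 1870 nM. Compound 3 `NC(=O)c1c(NC(=O)c2ccccc2Cl)sc2c1CCN(C(=S)Nc1ccc(C(F)(F)F)cc1)C2` gives 7090 nM, the second highest number of the three; its nearest neighbour is compound 1 and its furthest is compound 2. Within the data shown here, the single step that can be read within the set, a 3.8-fold higher number from compound 2 to compound 3 (0.58 log units; beyond the scatter), moves the trifluoromethyl group within the same ring and is modest but beyond the scatter.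

Compound 4 `NC(=O)c1c(NC(=O)c2ccccc2Cl)sc2c1CCN(C(=S)Nc1cccnc1)C2` differs from compound 3 by pyridin-3-yl in place of 4-(trifluoromethyl)phenyl on an amide-type nitrogen. Among the measured compounds shown here, no measured step bears directly on this exchange: nothing in the set replaces the carbon-only aromatic ring on the thiourea nitrogen with a ring holding a nitrogen atom, and the step from compound 2 to compound 3 speaks only to where the trifluoromethyl group sits. Compound 1 differs from the two thioureas in more than one place, so its value shows only that both thioureas sit at lower numbers than it does. Lacking an anchor, the expected step of a 1.1-fold higher number from compound 3 to compound 4 (0.05 log units; within the scatter) is judged to be within the scatter, with its direction uncertain. Compound 4 is therefore estimated at 8000 nM, within a range from 2500 nM to 25000 nM.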

Compound 4, half-maximal inhibitory concentration: 38600 nM
For compound 4 the middle estimate is 4.8-fold (0.68 log units) below the measured one; measured number above the stated range.
By their numbers in this assay, from the lowest: compound 2; then compound 3; then compound 1; then compound 4.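

In this assay the group on the thiourea nitrogen does more than register where a trifluoromethyl group sits: pyridin-3-yl in place of 4-(trifluoromethyl)phenyl brings a 5.4-fold higher number from compound 3 to compound 4 (0.74 log units; beyond the scatter) and, set against 2-(trifluoromethyl)phenyl, a 21-fold higher number from compound 2 to compound 4 (1.31 log units; beyond the scatter) as the largest step among the four compounds. Both earlier thioureas stood at lower numbers than compound 1, yet this one reverses that order with a 2.1-fold higher number from compound 1 to compound 4 (0.31 log units; beyond the scatter) and leaves compound 4 as the weakest of the four, so the thiourea link alone does not secure a lower number than compound 1 shows. Nothing at hand accounts for the size of this change.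

The exchange removes the trifluoromethyl group and brings in the ring nitrogen in a single move, and the compounds shown cannot separate the two, which an unsubstituted phenyl on the same nitrogen would begin to do. They also leave open whether pyridin-2-yl, pyridin-4-yl or a pyridine ring carrying a trifluoromethyl group would give numbers like that of pyridin-3-yl or like those of the trifluoromethylphenyl thioureas.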